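The source may hold more compounds than are shown below. What is called first, only, known or untested is meant among the compounds shown, and "the series" means these compounds.

Compound 1 `C[C@H](O)[C@@H](CCc1ccc(C(F)(F)F)cc1)n1cnc2c(N)ncnc21` in an assay on isolated protein for inhibition of adenosine deaminase (Bos taurus), with a stated time of 5 min; a lower number here means a stronger inhibitor, a higher number a weaker inhibitor: 5.2 nM
Compound 2 `C[C@H](O)[C@@H](CCC1CCCCC1)n1cnc2c(N)ncnc21`: 1.9 nM
Compound 3 `C[C@H](O)[C@@H](CSc1ccccc1)n1cnc2c(N)ncnc21`: 135 nM

Among these three, compound 3 gives the highest number in this assay, with compound 1 and compound 2 both well beneath it. For the measured compounds named here, the single measured step that reaches compound 3 is a 71-fold higher number from compound 2 to compound 3 (1.85 log units; beyond the scatter), a large loss. Compound 4 `Cc1cccc(SC[C@H]([C@H](C)O)n2cnc3c(N)ncnc32)c1` differs from compound 3 by methyl in place of hydrogen on an aromatic carbon. Going by the values given here, no measured step changes the phenyl of the phenylsulfanyl group, so nothing among the data speaks directly to this substitution; the expectation can rest only on the change being one carbon added to an aromatic ring. Compound 4 is therefore expected to show a 1.2-fold lower number from compound 3 to compound 4 (0.09 log units; within the scatter), a step not beyond the scatter in either direction. The estimate for compound 4 in this assay is 110 nM, with a range from 40 nM to 350 nM.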

Compound 4, inhibition constant: 49 nM
Beside the measured number, compound 4's estimate is 2.2-fold (0.35 log units) above it, within the range that was stated.
By their numbers in this assay, from the lowest: compound 2; then compound 1; then compound 4; then compound 3.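

In this assay, the earlier step changed the whole group on the chain, whereas this one leaves the phenylsulfanyl link in place and alters only its ring. Going from phenyl to 3-methylphenyl gives a 2.8-fold lower number from compound 3 to compound 4 (0.44 log units; beyond the scatter), so a single methyl on the aromatic carbon, meta to a large group, already moves the number modestly beyond the scatter. The ring of this group is therefore a place where a small addition registers.

As far as these compounds go, whether another position on the ring, or a chlorine, a methoxy or an amine in place of the methyl, would do the same remains open. Nothing available accounts for the step.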